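A hydroxy to methoxy step in a level series

The source may report more compounds than this note shows. Statements on the series, on what has been measured and on what is new or still open speak of the compounds shown alone.

Compound 1 `c1ccc(-c2ccc(-c3ccc(-c4nc5ccccc5[nH]4)cc3)cc2)cc1`: 41200 nM
Compound 2 `FC(F)(F)c1ccc(-c2ccc(-c3ccc(-c4nc5ccccc5[nH]4)cc3)cc2)cc1`: 45200 nM
Compound 3 `Oc1ccc(-c2ccc(-c3ccc(-c4nc5ccccc5[nH]4)cc3)cc2)cc1`: 47000 nM

All three values come from a functional assay on PC-3 cells (Homo sapiens) for inhibition, read by sulforhodamine B assay (a lower number here means a stronger inhibitor of growth, a higher number a weaker inhibitor of growth), and compound 3 stands level with the other two, within the scatter of both. Compound 4 `COc1ccc(-c2ccc(-c3ccc(-c4nc5ccccc5[nH]4)cc3)cc2)cc1` turns hydroxy into methoxy, with methyl in place of hydrogen on an oxygen on an aromatic ring. Among the measured compounds shown here, no measured step makes this exact change. The closest evidence is three exchanges among hydrogen, trifluoromethyl and hydroxy: a 1.1-fold higher number from compound 1 to compound 2 (0.04 log units; within the scatter), a 1.1-fold higher number from compound 1 to compound 3 (0.06 log units; within the scatter) and a 1.0-fold higher number from compound 2 to compound 3 (0.02 log units; within the scatter). None leaves the scatter, so no change beyond the scatter is expected in either direction in this assay. The expected step is a 1.0-fold lower number from compound 3 to compound 4 (0.02 log units; within the scatter). For compound 4 the estimated value is 45000 nM, with an expected range from 25000 nM to 80000 nM.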

Compound 4, concentration for 50% growth inhibition: 100000 nM
The estimate for compound 4 lay 2.2-fold (0.35 log units) below the measured number; the whole stated range lies below it.
By their numbers in this assay, from the lowest: compounds 1, 2 and 3 (each within the scatter of the next); then compound 4.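

Methyl in place of hydrogen on the oxygen on an aromatic ring is the first change here to leave the scatter in this assay (a 2.1-fold higher number from compound 3 to compound 4 (0.33 log units; beyond the scatter)), whereas hydrogen, trifluoromethyl and hydroxy stood level. Methoxy also separates from trifluoromethyl (a 2.2-fold higher number from compound 2 to compound 4 (0.34 log units; beyond the scatter)) and from hydrogen (a 2.4-fold higher number from compound 1 to compound 4 (0.39 log units; beyond the scatter)), which makes compound 4 the weakest inhibitor of growth of the four. Nothing measured here accounts for this shift.

Still open, as far as these compounds go, is whether the weaker inhibition is particular to methoxy or extends to a longer chain such as ethoxy. From the compounds shown here alone, how an amine or a carboxylic acid at this place would read also remains unknown.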